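A few compounds are considered here, and "the series" means these few. Any claim that something is new, unique, unknown or untested is made for them only; others in the source may bear on it.

Working notes on the series. The shared core of compound 1 `COc1ccc(NC(=O)/C=C/C(=O)N2C/C(=C\c3ccc([N+](=O)[O-])cc3)C(=O)/C(=C/c3ccc([N+](=O)[O-])cc3)C2)cc1` carries a fumaramide chain ending in a 4-methoxyphenyl amide. In a functional assay on L1210 cells (Mus musculus) for cytotoxicity (on this read-out lower numbers stand for stronger inhibition and higher numbers for weaker inhibition), compound 1 gives 2900 nM. Among the compounds with values here, the only other number so far belongs to compound 2 `Cc1cccc(C)c1NC(=O)/C=C/C(=O)N1C/C(=C\c2ccccc2)C(=O)/C(=C/c2ccccc2)C1`, which differs in several places at once; in this assay compound 2 gives 22000 nM. Compound 1 stands at the lower of the two numbers, and the gap to compound 2 lies beyond the scatter, though with two compounds and no single-point comparison between them nothing can be said about which of their differences matters.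

Compound 3 `O=C(/C=C/C(=O)N1C/C(=C\c2ccc([N+](=O)[O-])cc2)C(=O)/C(=C/c2ccc([N+](=O)[O-])cc2)C1)Nc1ccccc1` is not yet measured. It differs from compound 1 in one place only: hydrogen in place of methoxy on an aromatic carbon, on an aromatic carbon of a six-membered aromatic ring of carbon only, para to a large group. Within the data shown here, no measured pair shows the effect of this change, so the direction is open. The expectation is a step from compound 1 to compound 3 of a 1.4-fold higher number from compound 1 to compound 3 (0.14 log units; within the scatter), that is, within or at the edge of the scatter. Compound 3 is accordingly estimated at 4000 nM, with a range from 1500 nM to 12000 nM.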

Compound 3, half-maximal inhibitory concentration: 1800 nM
For compound 3 the middle estimate is 2.2-fold (0.35 log units) above the measured one; measured number inside the range.
By their numbers in this assay, from the lowest: compounds 3 and 1 (each within the scatter of the next); then compound 2.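

Within the data shown here, this is the first comparison that changes one place only. In this assay, hydrogen in place of methoxy on the aromatic carbon para to a large group gives a 1.6-fold lower number from compound 1 to compound 3 (0.21 log units; within the scatter), so the 4-methoxyphenyl and phenyl amide ends cannot be told apart on this read-out while the rest of compound 1 stays fixed. The methoxy group is therefore not required for compound 3 to stay within the scatter of compound 1, although no separate measurement is available to explain this result.

This single pair leaves open whether a different group on the same aromatic carbon, such as an amine, a carboxylic acid, a chlorine atom or a longer alkoxy chain, would move the number beyond the scatter. Compound 2, at 22000 nM, still differs from compound 1 and compound 3 in more than one place, so its value cannot be assigned to any single difference, and the same methoxy-to-hydrogen change remains unread on any other background.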